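Swapping methyl for methoxy on a shared thiazole-based core

The source may report more compounds than this note shows. Statements on the series, on what has been measured and on what is new or still open speak of the compounds shown alone.

Compound 1 `Cc1ccc(-c2cs/c(=N/NC(=O)CSc3nnnn3C)n2-c2ccccc2)cc1` and compound 2 `COc1ccc(-c2cs/c(=N/NC(=O)CSc3nnnn3C)n2-c2ccccc2)cc1` differ by one change, (methoxy in place of methyl on an aromatic carbon), and in an ADME assay on NIH3T3 cells (Mus musculus) for cytotoxicity, read by MTT assay, with a stated time of 24 h (a lower number here means a stronger inhibitor, a higher number a weaker inhibitor), compound 1 gives 243 ug/mL while compound 2 gives 45 ug/mL, a step of a 5.4-fold lower number from compound 1 to compound 2 (0.73 log units; beyond the scatter). Compound 3 `Cc1ccc(-c2cs/c(=N/NC(=O)CSc3ncccn3)n2-c2ccccc2)cc1` carries a different sulfur-bound ring, (pyrimidin-2-yl in place of 1-methyl-1H-tetrazol-5-yl on a sulfur). In this assay compound 3 reaches only a limit, > 500 ug/mL, not a number. The step of an at least 2.0-fold higher number from compound 1 to compound 3 (0.31 log units; beyond the scatter) is therefore given only as a bound because compound 3 sits at the limit of > 500 ug/mL in this assay, at which 1 of the 3 values shown sits. Compound 4 `COc1ccc(-c2cs/c(=N/NC(=O)CSc3ncccn3)n2-c2ccccc2)cc1` relates to compound 3 as compound 2 relates to compound 1, through (methoxy in place of methyl on an aromatic carbon), the same change at the same place. For compound 4 a step of an at least 3.3-fold lower number from compound 3 to compound 4 (0.52 log units; beyond the scatter) is expected, resting on compound 1 and compound 2 and their step of a 5.4-fold lower number from compound 1 to compound 2 (0.73 log units; beyond the scatter). Compound 4 is therefore estimated at 150 ug/mL, between 50 ug/mL and 500 ug/mL, though a limit may again be reported.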

Compound 4, half-maximal inhibitory concentration: 450 ug/mL
Compound 4: middle estimate off by 3.0-fold (0.48 log units), on the low side; the measured number falls inside the stated range.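

In this assay compound 3 stands at a limit, > 500 ug/mL, not a number. Methoxy in place of methyl can therefore be read on this core only as a bound (an at least 1.1-fold lower number from compound 3 to compound 4 (0.04 log units; that floor lies within the scatter)), so these data neither show nor exclude that the change carries over at the same size: the same change on two cores in this assay, a 5.4-fold lower number (0.73 log units; beyond the scatter) from compound 1 to compound 2 and an at least 1.1-fold lower number (0.04 log units; that floor lies within the scatter) from compound 3 to compound 4; the limit leaves it open whether they differ. As far as these compounds go, the sulfur-bound ring swap can be read in full only on the methoxy pair (a 10-fold higher number from compound 2 to compound 4 (1.00 log units; beyond the scatter)), and it points the same way as the bound on the methyl pair, though its size there stays unknown: the same change on two cores in this assay, an at least 2.0-fold higher number (0.31 log units; beyond the scatter) from compound 1 to compound 3 and a 10-fold higher number (1.00 log units; beyond the scatter) from compound 2 to compound 4; the limit leaves it open whether they differ.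

The compounds shown leave open how an amine or a carboxylic acid would read on that aromatic carbon. They also leave open whether the ring swap behaves alike with a chloro group there.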